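Swapping methyl for chloro on a nitro-bearing cinnamoyl sulfonamide

The source may report more compounds than this note shows. Statements on the series, on what has been measured and on what is new or still open speak of the compounds shown alone.

Measured compounds:
compound 1 `Cc1ccc(S(=O)(=O)NC(=O)/C=C/c2ccccc2)cc1` — 13.8 ug/mL
compound 2 `O=C(/C=C/c1ccccc1)NS(=O)(=O)c1ccc(Cl)cc1` — 2.2 ug/mL
compound 3 `Cc1ccc(S(=O)(=O)NC(=O)/C=C/c2ccccc2[N+](=O)[O-])cc1` — 10.3 ug/mL

Three close relatives have been tested in a functional assay on B16-F10 cells (Mus musculus) for antiproliferative activity, read by ELISA and MTT assay, with a stated time of 48 h; a lower number here means a stronger inhibitor, a higher number a weaker inhibitor. Compound 1 `Cc1ccc(S(=O)(=O)NC(=O)/C=C/c2ccccc2)cc1` gives 13.8 ug/mL in this assay. Going by the values given here, compound 2 `O=C(/C=C/c1ccccc1)NS(=O)(=O)c1ccc(Cl)cc1` gives 2.2 ug/mL, and the step of a 6.3-fold lower number from compound 1 to compound 2 (0.80 log units; beyond the scatter) is the only change in the set that leaves the scatter. Compound 3 `Cc1ccc(S(=O)(=O)NC(=O)/C=C/c2ccccc2[N+](=O)[O-])cc1` gives 10.3 ug/mL; the step of a 1.3-fold lower number from compound 1 to compound 3 (0.13 log units; within the scatter) stays within the scatter, so compound 3 and compound 1 cannot be told apart on these numbers, while compound 2 sits well beyond both of them with the lower number.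

Compound 4 `O=C(/C=C/c1ccccc1[N+](=O)[O-])NS(=O)(=O)c1ccc(Cl)cc1` has not yet been measured. It differs from compound 3 in one place: chloro in place of methyl on an aromatic carbon. Among the compounds with values here, this is the same change that carried compound 1 to compound 2, and the only measured step that bears on it is a 6.3-fold lower number from compound 1 to compound 2 (0.80 log units; beyond the scatter). On that single precedent, compound 4 is expected to show a lower number than compound 3 in this assay by a step of about a 6.1-fold lower number from compound 3 to compound 4 (0.78 log units; beyond the scatter). Compound 4 is therefore estimated at 1.7 ug/mL, with a likely range from 0.7 ug/mL to 4.5 ug/mL.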

Compound 4, half-maximal inhibitory concentration: 6.6 ug/mL
Compound 4: middle estimate off by 3.9-fold (0.59 log units), on the low side; measured number outside the range, above it.
By their numbers in this assay, from the lowest: compound 2; then compounds 4, 3 and 1 (each within the scatter of the next, the first and the last beyond it).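

In this assay, going by these compounds alone, the change from 4-methylphenyl to 4-chlorophenyl no longer separates its pair once the nitro group is present, as a 1.6-fold lower number from compound 3 to compound 4 (0.19 log units; within the scatter) shows. Nitro in place of hydrogen, which could not be told from no change on the methyl-bearing core, does leave the scatter on the chloro-bearing core, with a 3.0-fold higher number from compound 2 to compound 4 (0.48 log units; beyond the scatter). The two changes therefore do not add up independently across these four compounds, and the size of the chloro step depends on the core that carries it: the same change on two cores in this assay, a 6.3-fold lower number (0.80 log units; beyond the scatter) from compound 1 to compound 2 and a 1.6-fold lower number (0.19 log units; within the scatter) from compound 3 to compound 4, 4.0-fold (0.60 log units) apart, beyond the scatter of two such steps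

The compounds shown leave open whether bromo or methoxy in place of the chloro would also give a step that depends on the core. They also leave open whether an amine or a carboxylic acid in place of the nitro group would keep the large step seen on the core of compound 1 or the small one seen on the core of compound 3.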